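Benzylidene substitution in a pyrazolone-thiazole series: cytotoxicity note

A few compounds are considered here, and "the series" means these few. Any claim that something is new, unique, unknown or untested is made for them only; others in the source may bear on it.

The measured set consists of three compounds on a shared core. Compound 1 `CC(=O)c1nn(-c2ccc(Cl)cc2)/c(=N/c2nc(-c3c(C)n(C)n(-c4ccccc4)c3=O)cs2)s1`, compound 2 `Cc1c(-c2csc(/N=C3\SCC(=O)N3c3ccccc3)n2)c(=O)n(-c2ccccc2)n1C` and compound 3 `Cc1c(-c2csc(/N=C3\S/C(=C\c4ccccc4)C(=O)N3c3ccccc3)n2)c(=O)n(-c2ccccc2)n1C` were all run in a functional assay on A549 cells (Homo sapiens) for cytotoxicity, read by sulforhodamine B assay, with a stated time of 72 h; on this read-out higher numbers stand for weaker inhibition and lower numbers for stronger inhibition. For compound 1 the read-out is a limit of the assay, > 100000 nM. For compound 2 the read-out is likewise a limit, > 100000 nM. For compound 3 the read-out is again a limit, > 100000 nM. Among the compounds with values here, compound 3 therefore stands where the whole set stands, as summarised in the limit of > 100000 nM in this assay, at which 3 of the 3 values shown sit; no step between measured compounds is available and no compound can be ranked against another.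

Compound 4 `Cc1c(-c2csc(/N=C3\S/C(=C\c4ccc(N(C)C)cc4)C(=O)N3c3ccccc3)n2)c(=O)n(-c2ccccc2)n1C` differs from compound 3 by dimethylamino in place of hydrogen on an aromatic carbon. With every measured member sitting at the limit, the expected step from compound 3 to compound 4 is a step that the limit leaves unreadable from compound 3 to compound 4, that is, no change beyond the scatter, and the expectation is that the read-out remains a limit. On that basis compound 4 is estimated at 120000 nM in this assay, with a range from 30000 nM to 500000 nM.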

Compound 4, half-maximal inhibitory concentration: > 100000 nM
Compound 4: no number, only a limit; the forecaster's own chance of this, stated with the estimate: 80%; the middle value lies beyond the limit too.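

No step from compound 3 to compound 4 can be read in this assay, since both read-outs are limits: the limit of > 100000 nM in this assay, at which 4 of the 4 values shown sit.

The compounds shown leave open whether any member of this series has a numerical potency on this read-out, and what dimethylamino in place of hydrogen would then change.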